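Thiocarbamoyl arm on the ring nitrogen of compound 1

A few compounds are considered here, and "the series" means these few. Any claim that something is new, unique, unknown or untested is made for them only; others in the source may bear on it.

Compound 1 `Cn1cccc1-c1cc(-c2ccc(Br)cc2)[nH]c(=O)c1C#N` was tested in a functional assay on SF-539 cells (Homo sapiens) for cytotoxicity, read by sulforhodamine B assay, with a stated time of 48 h (on this read-out lower numbers stand for stronger inhibition of growth and higher numbers for weaker inhibition of growth), where compound 1 gives 89100 nM. Of the two numbers shown, compound 1 sits at the top, though compound 2 `COc1ccc(-c2cc(-c3cccn3C)c(C#N)c(=O)[nH]2)cc1OC` gives 67600 nM, a figure within the scatter of that of compound 1. Compound 3 `COc1ccc(-c2cc(-c3cccs3)[nH]c(=O)c2C#N)cc1` reaches only a limit in this assay, > 100000 nM, which is the limit of > 100000 nM in this assay, at which 1 of the 3 values shown sits. Compound 4 `Cn1cccc1-c1cc(-c2ccc(Br)cc2)n(C(=S)Nc2ccc(F)cc2)c(=O)c1C#N` differs from compound 1 by a group of 10 heavy atoms (7 carbon, 1 nitrogen, 1 fluorine, 1 sulfur; one six-membered aromatic ring of carbon only) in place of a hydrogen atom, on an aromatic nitrogen. Among the compounds with values here, no measured pair shows a change of this kind, so the expectation rests on compound 1 alone. A moderate gain in growth inhibition is expected, a 3.0-fold lower number from compound 1 to compound 4 (0.47 log units; beyond the scatter). Compound 4 is therefore estimated at 30000 nM, with a range from 8000 nM to 100000 nM.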

Compound 4, concentration for 50% growth inhibition: > 100000 nM
Compound 4 ended at the assay's limit; the forecaster's own chance of this, stated with the estimate: 20%; middle value at least 3.3-fold (0.52 log units) from the limit.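

In this assay, within the data shown here, the thiocarbamoyl arm on the aromatic nitrogen gives an at least 1.1-fold higher number from compound 1 to compound 4 (0.05 log units; that floor lies within the scatter), so this position, unchanged in the earlier compounds, shows no gain in growth inhibition with this group. Compound 4 stands at a limit of the assay rather than at a number, and it joins compound 3 there: the limit of > 100000 nM in this assay, at which 2 of the 4 values shown sit.

How far compound 4 lies past that limit cannot be read from these data. The compounds shown also leave open whether a methyl group or an acetyl group on this nitrogen would fare differently.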